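Notes on the step from compound 2 to compound 3

The source may hold more compounds than are shown below. What is called first, only, known or untested is meant among the compounds shown, and "the series" means these compounds.

Two compounds of the series have so far been run in a functional assay on cells for agonist activity at C-X-C chemokine receptor type 4 (Homo sapiens), read by fluorescence and calcium flux, with a stated time of 90 s; on this read-out lower numbers stand for an effect already at smaller amounts and higher numbers for an effect only at larger amounts of compound. Compound 1 `c1ccc2c(c1)CN[C@@H](CN(CCCCNCC1CCNCC1)[C@H]1CCCc3cccnc31)C2` returns only the limit of the assay, > 30000 nM in this assay. Compound 2 `CC(C)(N)CCCN(C[C@H]1Cc2ccccc2CN1)[C@H]1CCCc2cccnc21` likewise returns only the limit, > 30000 nM in this assay. Within the data shown here, the single recorded step, a step that the two limits leave unreadable from compound 1 to compound 2, is consequently of no readable size, as both values sit at the limit of > 30000 nM in this assay, at which 2 of the 2 values shown sit. Compound 2 therefore stands at the limit, with no number that would place it against any other member of the series.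

Compound 3 `CC(C)(CCN(C[C@H]1Cc2ccccc2CN1)[C@H]1CCCc2cccnc21)CNCC1CCOCC1` has not been measured. It differs from compound 2 by a group of 12 heavy atoms (10 carbon, 1 nitrogen, 1 oxygen; one six-membered non-aromatic ring with 1 hetero atom) in place of a group of 5 heavy atoms (4 carbon, 1 nitrogen; no ring), on a saturated chain carbon, two bonds along the chain from an amine nitrogen. Among the measured compounds shown here, no measured step bears on this change: the one recorded step concerns a different position and is itself unreadable, so it gives neither size nor direction. The step expected in this assay, a number no higher from compound 2 to compound 3 (the limit leaves the size open), is thus estimated without any anchor from the measured pairs. On that footing compound 3 is expected to give about 30000 nM in this assay, with an estimated range from 5000 nM to 100000 nM, and most probably another limit rather than a number.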

Compound 3, half-maximal effective concentration: > 30000 nM
Compound 3: only a limit was reported; the forecaster's own chance of this, stated with the estimate: 70%; the middle value sits exactly at the limit.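

Compound 1, compound 2 and compound 3 all return only a limit in this assay, so no step among them can be read: the limit of > 30000 nM in this assay, at which 3 of the 3 values shown sit.

The compounds shown leave open whether any member of the series gives a number rather than a limit, and what size or direction these changes of group have.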